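The source may report more compounds than this note shows. Statements on the series, on what has been measured and on what is new or still open speak of the compounds shown alone.

In a functional assay on K562 cells (Homo sapiens) for antiproliferative activity, read by MTT assay, with a stated time of 5 days (on this read-out lower numbers stand for stronger inhibition and higher numbers for weaker inhibition), the three measured compounds stand as follows:

Compound 1, `COc1ccc(C(=Cc2ccc(OC)c([N+](=O)[O-])c2)C(=O)c2cc(OC)c(OC)c(OC)c2)cc1`, gives 2660000 nM.
Compound 2, `COc1ccc(C=C(C(=O)c2cc(OC)c(OC)c(OC)c2)c2ccc(C)cc2)cc1[N+](=O)[O-]`, gives 2430000 nM.
Compound 3, `COc1ccc(C(=Cc2ccc(OC)c(F)c2)C(=O)c2cc(OC)c(OC)c(OC)c2)cc1`, gives 450000 nM.

Compound 1 and compound 2 differ by methyl in place of methoxy on an aromatic carbon, and the step of a 1.1-fold lower number from compound 1 to compound 2 (0.04 log units; within the scatter). Compound 1 and compound 3 differ by fluoro in place of nitro on an aromatic carbon, and here the step of a 5.9-fold lower number from compound 1 to compound 3 (0.77 log units; beyond the scatter). Compound 3 therefore holds the lowest number of the three, with steps beyond the scatter to both compound 1 and compound 2.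

Compound 4, `COc1ccc(C=C(C(=O)c2cc(OC)c(OC)c(OC)c2)c2ccc(C)cc2)cc1F`, is not yet measured. It differs from compound 3 by methyl in place of methoxy on an aromatic carbon. This is the same change that leads from compound 1 to compound 2, at the same place; the two cores differ by fluoro in place of nitro on an aromatic carbon. For compound 4 a step of a 1.1-fold lower number from compound 3 to compound 4 (0.03 log units; within the scatter) is expected, because a 1.1-fold lower number from compound 1 to compound 2 (0.04 log units; within the scatter) lay within the scatter, so the same change on the core of compound 3 is expected to leave the number near that of compound 3. Compound 4 is thus estimated at 420000 nM, with a likely range from 160000 nM to 1200000 nM.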

Compound 4, half-maximal inhibitory concentration: 570000 nM
Estimate against measurement, compound 4: 1.4-fold (0.13 log units) below; the measured number falls inside the stated range.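

In this assay, methyl in place of methoxy gave a 1.3-fold higher number from compound 3 to compound 4 (0.10 log units; within the scatter), which matches the earlier step on the other core: the same change on two cores in this assay, a 1.1-fold lower number (0.04 log units; within the scatter) from compound 1 to compound 2 and a 1.3-fold higher number (0.10 log units; within the scatter) from compound 3 to compound 4, 1.4-fold (0.14 log units) apart, within the scatter of two such steps. Fluoro in place of nitro gave a 4.3-fold lower number from compound 2 to compound 4 (0.63 log units; beyond the scatter), and this too matches its earlier step: the same change on two cores in this assay, a 5.9-fold lower number (0.77 log units; beyond the scatter) from compound 1 to compound 3 and a 4.3-fold lower number (0.63 log units; beyond the scatter) from compound 2 to compound 4, 1.4-fold (0.14 log units) apart, within the scatter of two such steps. Across these four compounds, then, each change carried from one core to the other with no difference beyond the scatter, the methyl change leaving the number in place and the fluoro change lowering it on both; this rests on just two cores and one pair of steps per change, so it does not show that either change would carry to other cores in the series, nor why the steps take the sizes they do.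

The compounds shown leave open whether other groups at these places, such as an amine, a chlorine or a carboxylic acid, would carry across the cores in the same way. From the compounds shown here alone, whether these steps hold outside this assay also stays open.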